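Trifluoromethyl for chloro on a shared core

The compounds below may be only part of what the source reports. "The series", "measured", "known", "first", "only" and "open" are said of these compounds alone.

Of the compounds shown here, three have been measured in a physicochemical assay for solubility, at pH 7; on this read-out higher numbers stand for higher solubility and lower numbers for lower solubility. Compound 1 `O=C(CN1CCC(c2ccccc2)(c2ccccc2)C1=O)N1CCN(C(c2ccccc2)c2ccccc2)CC1` gives only a limit of the assay, not a number: < 25000 nM. Compound 2 `O=C(CN1CCCC(c2ccc(F)cc2)(c2ccc(F)cc2)C1=O)N1CCN(C(c2ccccc2)c2ccccc2)CC1` likewise returns a limit, < 25000 nM. Compound 3 `O=C(CN1CCCC(c2ccccc2)(c2ccccc2)C1=O)N1CCN(Cc2cccc(Cl)c2)CC1` stands at the same limit, < 25000 nM. No pair among these three differs in a single place, so no measured step can be drawn between them; all that can be said is that every value so far sits at the floor of the read-out, which the limit of < 25000 nM in this assay, at which 3 of the 3 values shown sit, records for all three. Where compound 3 stands is therefore a bound, not a position on a scale.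

Compound 4 `O=C(CN1CCCC(c2ccccc2)(c2ccccc2)C1=O)N1CCN(Cc2cccc(C(F)(F)F)c2)CC1` is the compound that comes next. It differs from compound 3 in one change: trifluoromethyl in place of chloro on an aromatic carbon, the same difference reading 3-chlorobenzyl to 3-(trifluoromethyl)benzyl. Among the measured compounds shown here, with no measured step to lean on, the expected step from compound 3 to compound 4 is a step that the limit leaves unreadable from compound 3 to compound 4, that is none beyond the scatter, and the read-out is expected to remain at the limit. Compound 4 is accordingly estimated at 10000 nM in this assay, with a range from 3000 nM to 30000 nM.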

Compound 4, solubility: < 25000 nM
Compound 4: no number, only a limit; the forecaster's own chance of this, stated with the estimate: 80%; the middle value lies beyond the limit too.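

No step can be read from compound 3 to compound 4, since each of the two gives only a limit of the assay and not a number: the limit of < 25000 nM in this assay, at which 4 of the 4 values shown sit.

The compounds shown leave open how trifluoromethyl and chloro on this shared core compare in this assay, and where any of the four compounds truly lies on that scale.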